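The source may hold more compounds than are shown below. What is called first, only, known or untested is meant among the compounds shown, and "the series" means these compounds.

Measured so far:
compound 2, `O=c1c2cnn(-c3ccc(F)cc3)c2ncn1CC1(O)CCN(Cc2ccccc2F)CC1`: 9800 nM
compound 3, `O=c1c2cnn(-c3ccc(F)cc3)c2ncn1CC1(O)CCN(Cc2ccccc2Br)CC1`: 3100 nM
compound 1, `O=c1c2cnn(-c3ccc(F)cc3)c2ncn1CC1(O)CCN(Cc2ccccc2)CC1`: "not determined" (no result reported)

In an assay on Sf21 cells for inhibition of ubiquitin carboxyl-terminal hydrolase 7 (Homo sapiens), read by spectrophotometry, with stated times of 30 min and 2 h (a higher number here means a weaker inhibitor, a lower number a stronger inhibitor), compound 2 gives 9800 nM, the highest of the two numbers shown; its nearest neighbour, compound 3, gives 3100 nM. Going by the values given here, the one step among the measured compounds is a 3.2-fold lower number from compound 2 to compound 3 (0.50 log units; beyond the scatter), a modest step and beyond the scatter. Compound 1, which carries the unsubstituted benzyl, has no number in this assay.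

Compound 4, `COC(=O)c1ccc(CN2CCC(O)(Cn3cnc4c(cnn4-c4ccc(F)cc4)c3=O)CC2)c(F)c1`, differs from compound 2 by methoxycarbonyl in place of hydrogen on an aromatic carbon. The change keeps the fluoro group of compound 2 and adds a substituent elsewhere on the same ring; the measured step from compound 2 to compound 3 concerns the exchange of one halogen for another at a single position, so it does not bear directly on an added methoxycarbonyl. Among the compounds with values here, no measured compound carries a group of this kind on the benzyl ring. The working expectation is a step of a 1.6-fold lower number from compound 2 to compound 4 (0.21 log units; within the scatter), with no firm direction to be read from the data, and wide uncertainty. Compound 4 is therefore estimated at 6000 nM, with a range of 1500 nM to 25000 nM.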

Compound 4, half-maximal inhibitory concentration: 800 nM
For compound 4 the middle estimate is 7.5-fold (0.88 log units) above the measured one; the measured number lies below the stated range.
By their numbers in this assay, from the lowest: compound 4; then compound 3; then compound 2.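

In this assay, going by these compounds alone, the earlier compounds spoke only to exchanging one halogen for another, whereas methoxycarbonyl in place of hydrogen, meta to the fluoro group and para to a large group, gives a 12-fold lower number from compound 2 to compound 4 (1.09 log units; beyond the scatter) and so opens a second place on the benzyl ring where the number moves. The 2-fluoro-4-(methoxycarbonyl)benzyl compound also beats the bromo compound, with a 3.9-fold lower number from compound 3 to compound 4 (0.59 log units; beyond the scatter) as the printed step, which makes compound 4 the most potent of the three with numbers and puts this change ahead of the halogen exchange in size. No measurement here accounts for the size of this step.

Open, on these data alone, is whether a carboxylic acid, a primary amide or a nitrile in the same place would give a similar number. Also open, as far as these compounds go, is whether the step carries over with bromo in place of fluoro.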